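Aryl Returns at the Ester-Bearing Carbon

The source may report more compounds than this note shows. Statements on the series, on what has been measured and on what is new or still open speak of the compounds shown alone.

The series shares one core. Compound 1 `C=C(C(=O)c1ccc(OC)cc1)C(OC(=O)c1ccccc1)c1ccc(Cl)cc1Cl` gives 79200 nM in a functional assay on A549 cells (Homo sapiens) for inhibition, read by XTT assay, with a stated time of 48 h; a higher number here means a weaker inhibitor, a lower number a stronger inhibitor. Compound 2 `C=C(C(=O)c1ccc(OC)cc1)C(OC(=O)c1ccccc1)C1CCCCC1` gives 62100 nM in this assay, and the step of a 1.3-fold lower number from compound 1 to compound 2 (0.11 log units; within the scatter) lies within the scatter. Compound 3 `C=C(C(=O)c1ccc(OC)cc1)C(C)OC(=O)c1ccccc1` reaches only a limit in this assay, namely > 100000 nM, so its number is not known, only the edge it sits beyond (the limit of > 100000 nM in this assay, at which 1 of the 3 values shown sits). Compound 4 `C=C(C(=O)c1ccc(OC)cc1)C(OC(=O)c1ccccc1)c1ccccc1Cl` differs from compound 3 by 2-chlorophenyl in place of methyl on a saturated chain carbon bound to a double-bonded chain carbon and an oxygen next to a carbonyl group. Within the data shown here, the steps that bear on this change are an at least 1.2-fold higher number from compound 1 to compound 3 (0.10 log units; that floor lies within the scatter) and an at least 1.6-fold higher number from compound 2 to compound 3 (0.20 log units; that floor lies within the scatter), both of them floors that sit within the scatter; each swaps the methyl for a larger ring at the same place. The change to compound 4 goes the other way, from methyl to 2-chlorophenyl, and compound 1, the nearest measured analogue with an aryl ring there, gives 79200 nM. Compound 4 is therefore expected to come out near compound 1, a step of an at least 1.2-fold lower number from compound 3 to compound 4 (0.09 log units; that floor lies within the scatter) from the limit of compound 3, with an estimate of 80000 nM and a range from 30000 nM to 200000 nM.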

Compound 4, half-maximal inhibitory concentration: 30500 nM
For compound 4 the middle estimate is 2.6-fold (0.42 log units) above the measured one; the range from low to high includes it.
By their numbers in this assay, from the lowest: compound 4; then compounds 2 and 1 (each within the scatter of the next). At a limit, above all of these: compound 3.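

In this assay, the change at the saturated chain carbon bound to a double-bonded chain carbon and an oxygen next to a carbonyl group now gives a step beyond the scatter, an at least 3.2-fold lower number from compound 3 to compound 4 (0.51 log units; beyond the scatter), and an aromatic ring also separates from cyclohexyl there, with a 2.0-fold lower number from compound 2 to compound 4 (0.31 log units; beyond the scatter). An aryl ring alone does not account for this, since the ring's substitution counts as well: a 2.6-fold lower number from compound 1 to compound 4 (0.41 log units; beyond the scatter), while compound 1, which also bears an aryl ring, stays within the scatter of compound 2. Compound 3 stands at a limit, so the step from methyl is a floor and not a measured size: the limit of > 100000 nM in this assay, at which 1 of the 4 values shown sits.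

The compounds shown leave open whether an unsubstituted phenyl ring would match 2-chlorophenyl at this place. They also do not settle how a fluorine, a methoxy group or an amine on that ring would compare.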